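Swapping the aryl group on the triazole of a naphthoquinone series

The compounds below may be only part of what the source reports. "The series", "measured", "known", "first", "only" and "open" are said of these compounds alone.

Of the compounds shown here, three sharing one core have been measured in an ADME assay on HepG2 cells (Homo sapiens) for cytotoxicity, read by MTT assay, with a stated time of 24 h; a higher number here means that more compound is tolerated, a lower number that less compound is tolerated. Compound 1 `CC(C)=CCC1=C(OCc2cn(-c3ccnc4cc(Cl)ccc34)nn2)C(=O)c2ccccc2C1=O` gives 1940000 nM; compound 2 `CC(C)=CCC1=C(OCc2cn(Cc3ccccc3)nn2)C(=O)c2ccccc2C1=O` gives 414000 nM; compound 3 `CC(C)=CCC1=C(OCc2cn(-c3ccc(C#N)cc3)nn2)C(=O)c2ccccc2C1=O` gives 707000 nM. Among these three numbers compound 3 stands second highest: its nearest neighbour is compound 2, a gap within the scatter, and its furthest is compound 1, a gap beyond the scatter. The change now in question is 2-methoxy-4-nitrophenyl in place of 4-cyanophenyl on an aromatic nitrogen, giving compound 4 `COc1cc([N+](=O)[O-])ccc1-n1cc(COC2=C(CC=C(C)C)C(=O)c3ccccc3C2=O)nn1`. Among the measured compounds shown here, two measured steps bear on it, since both alter the group on the same aromatic nitrogen: a 1.7-fold higher number from compound 2 to compound 3 (0.23 log units; within the scatter) and a 2.7-fold lower number from compound 1 to compound 3 (0.44 log units; beyond the scatter). Changes at this position have thus moved this assay by at most a modest amount, and the change to compound 4 also keeps a six-membered carbon ring at that place. The step of a 1.2-fold lower number from compound 3 to compound 4 (0.07 log units; within the scatter) is therefore expected to be small, likely within the scatter, with no clear direction. Compound 4 is estimated at 600000 nM, in a range from 250000 nM to 1500000 nM.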

Compound 4, half-maximal cytotoxic concentration: 701000 nM
Compound 4: middle estimate off by 1.2-fold (0.07 log units), on the low side; low and high end bracket the measured number.
By their numbers in this assay, from the lowest: compounds 2, 4 and 3 (each within the scatter of the next); then compound 1.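

In this assay the new group gives a 1.0-fold lower number from compound 3 to compound 4 (0.00 log units; within the scatter) and a 1.7-fold higher number from compound 2 to compound 4 (0.23 log units; within the scatter), so 2-methoxy-4-nitrophenyl on this aromatic nitrogen cannot be told apart from 4-cyanophenyl or benzyl, even though it carries more heavy atoms and hydrogen-bond acceptors than 4-cyanophenyl. Among the four compounds, only 7-chloroquinolin-4-yl stands apart, and the measured gap of a 2.8-fold lower number from compound 1 to compound 4 (0.44 log units; beyond the scatter) shows that compound 1 also lies clear of this newest substituted phenyl. Nothing available explains why these groups give the numbers they do.

The compounds shown leave open whether an amine, a carboxylic acid or a longer chain on this nitrogen would stay with compounds 2, 3 and 4 or come closer to compound 1. They also leave open how a phenyl bearing only the methoxy or only the nitro group would compare.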